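The compounds below may be only part of what the source reports. "The series", "measured", "known", "first", "only" and "open" are said of these compounds alone.

Measured so far:
Compound 1 `CCC1C(=O)N(C)c2cnc(Nc3ccc(S(=O)(=O)NCC(C)C)cc3)nc2N1c1ccn(C)n1` — 7300 nM
Compound 2 `CC[C@@H]1C(=O)N(C)c2cnc(-n3ccc4ccccc43)nc2N1C1CCCC1` — 6910 nM

Both numbers come from a functional assay on K562 cells (Homo sapiens) for antiproliferative activity, read by CCK-8 assay, with a stated time of 72 h; a lower number here means a stronger inhibitor of growth, a higher number a weaker inhibitor of growth. In that assay compound 1 gives 7300 nM and compound 2 gives 6910 nM. Of the two, the number for compound 2 sits nearer the low end, but its distance from compound 1 lies within the usual scatter of repeated measurements, so the two compounds cannot be told apart on activity, and neither can be called the more potent one.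

Compound 3 `CCNC(=O)c1ccc2c(ccn2-c2ncc3c(n2)N(C2CCCC2)[C@H](CC)C(=O)N3C)c1` has not yet been measured. It is related to compound 2 by a single change: ethylcarbamoyl in place of hydrogen on an aromatic carbon. Within the data shown here, no pair of measured compounds in this set carries this change, so there is no measured step to read its size from, and the two measured compounds differ from one another in several places at once, which gives no guidance either.

In this assay a modest step toward a lower number is expected, a 2.3-fold lower number from compound 2 to compound 3 (0.36 log units; beyond the scatter), though a step of no size beyond the scatter would not be surprising. For compound 3 the estimated value is 3000 nM, with a range from 800 nM to 12000 nM.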

Compound 3, concentration for 50% growth inhibition: 428 nM
Estimate against measurement, compound 3: 7.0-fold (0.85 log units) above; measured number below the stated range.
By their numbers in this assay, from the lowest: compound 3; then compounds 2 and 1 (each within the scatter of the next).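

In this assay, among these compounds, ethylcarbamoyl in place of hydrogen on an aromatic carbon gives a 16-fold lower number from compound 2 to compound 3 (1.21 log units; beyond the scatter) and so marks the first single change in this set with a measured size. The earlier compounds shown here could not show this, since they lie within the scatter of each other and differ in several places at once; the new step shows that this position, on the six-membered aromatic ring of carbon only, meta to a fused ring and para to a fused ring, can carry a substituent with a large effect on the growth-inhibition number. Nothing among the data shown bears on why this change has an effect of this size.

The compounds shown leave open whether the step depends on the whole ethylcarbamoyl group or on part of it, as a comparison with an unsubstituted carboxamide, a carboxylic acid, an amine or a longer chain on the amide nitrogen at this same position could tell. They also leave open whether ethylcarbamoyl would give a step of similar size on another carbon of the same ring.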